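The source may report more compounds than this note shows. Statements on the series, on what has been measured and on what is new or still open speak of the compounds shown alone.

The measured compounds:
compound 1, `CC(=O)N1CCN(c2ccc(Nc3nccc(-c4cn(C)c5ccccc45)n3)cc2)CC1`, 252 nM
compound 2, `CC(=O)N1CCCN(c2cccc(Nc3nccc(-c4n[nH]c5ccccc45)n3)c2)CC1`, 18 nM
compound 3, `CN1CCN(c2cccc(Nc3nccc(-c4c[nH]c5ncccc45)n3)c2)CC1`, 5 nM

Three compounds share a core and were tested in a functional assay on MV4-11 cells (Homo sapiens) for antiproliferative activity, read by resazurin assay, with a stated time of 72 h; on this read-out lower numbers stand for stronger inhibition of growth and higher numbers for weaker inhibition of growth. Compound 1 stands at the highest of the three numbers; compound 2 lies a good deal lower, beyond the scatter, and compound 3 lies lowest, again beyond the scatter. No two of these compounds differ in one place only, so their gaps are read as a whole and not as single steps.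

Compound 4, `CC(=O)N1CCN(c2ccc(Nc3nccc(-c4c[nH]c5ncccc45)n3)cc2)CC1`, has not yet been measured in this assay. It differs from compound 1 as follows: a group of 9 heavy atoms (7 carbon, 2 nitrogen; one five-membered aromatic ring with 1 hetero atom, one six-membered aromatic ring with 1 hetero atom) in place of a group of 10 heavy atoms (9 carbon, 1 nitrogen; one five-membered aromatic ring with 1 hetero atom, one six-membered aromatic ring of carbon only), on an aromatic carbon. The group that enters is the same one carried by compound 3, whose value of 5 nM is the lowest shown, while compound 2, which also carries a five-membered ring with a hydrogen-bond donor, sits at 18 nM. On this ground a step down, beyond the scatter, is expected from compound 1 to compound 4, of about a 10-fold lower number from compound 1 to compound 4 (1.00 log units; beyond the scatter). Compound 4 is therefore estimated at 25 nM in this assay, within a range from 8 nM to 80 nM.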

Compound 4, concentration for 50% growth inhibition: < 1 nM
Compound 4 was reported as a limit (the forecaster's own chance of this, stated with the estimate: 2%); at least 25-fold (1.39 log units) between middle value and limit.
By their numbers in this assay, from the lowest: compound 3; then compound 2; then compound 1. At a limit, below all of these: compound 4.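

In this assay, the group carried by compound 3 replaces 1-methyl-1H-indol-3-yl on the aromatic carbon next to the ring nitrogen, and this single change gives an at least 250-fold lower number from compound 1 to compound 4 (2.40 log units; beyond the scatter). Within the data shown here, the earlier compounds differed in more than one place, so only this pair shows that the group at this position alone can shift the number far beyond the scatter. Compound 4 stands at a limit of the assay, not at a number: the limit of < 1 nM in this assay, at which 1 of the 4 values shown sits.

The entering group differs from the leaving one both in its six-membered ring, which holds a hetero atom, and in having a hydrogen-bond donor, and this single step does not separate the two. A plain indol-3-yl group, with no methyl, would fall between them, and the compounds shown include no such group at this position.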